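The source may hold more compounds than are shown below. What is called first, only, known or untested is meant among the compounds shown, and "the series" means these compounds.

Compound 3 `O=C(O)Cc1sc(C(c2ccc(F)cc2)c2ccc(F)cc2)nc1-c1cccc(F)c1` was measured in an in vitro functional assay on HEK285-7 cells for antagonist activity at prostaglandin D2 receptor 2 (Homo sapiens), read by BRET and beta-arrestin recruitment (a higher number here means a larger maximal response, a lower number a smaller maximal response), and gives 80% there. Compound 1 `O=C(O)Cc1sc(C(c2ccccc2)c2ccccc2)nc1-c1ccc(F)cc1` gives 80% in this assay, so compound 1 and compound 3 sit level within the scatter, and together they are the highest of the three numbers. Compound 2 `O=C(O)Cc1sc(C2COc3ccccc3O2)nc1-c1ccc(Cl)cc1` gives 50% in this assay, a number beyond the scatter below compound 3.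

Compound 4 `N#Cc1cc(-c2nc(C(c3ccc(F)cc3)c3ccc(F)cc3)sc2CC(=O)O)ccc1F` differs from compound 3 in one place: 3-cyano-4-fluorophenyl in place of 3-fluorophenyl on an aromatic carbon. Within the data shown here, no measured pair shows this change, so the data give no direct guide to its size. The step of a number 5 percentage points lower from compound 3 to compound 4 (within the scatter) is expected to be small, at most a modest fall and likely within the scatter. Compound 4 is therefore expected to give about 75% in this assay, between 55% and 90%.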

Compound 4, largest response reached (reported as efficacy), in percent of the reference or control that the assay uses: 80%
For compound 4 the middle estimate is 5 percentage points below the measured one; the range from low to high includes it.
By their numbers in this assay, from the lowest: compound 2; then compounds 1, 3 and 4 (each within the scatter of the next).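

Putting 3-cyano-4-fluorophenyl in place of 3-fluorophenyl on this aromatic carbon gives no change at the digits printed from compound 3 to compound 4 (within the scatter) in this assay. Among these compounds, this is the first one-place comparison in the set, and it shows that this position accepts a larger aryl group bearing a nitrile without a shift in maximal response beyond the scatter. Nothing measured here offers a reason for this outcome.

The result does not separate the nitrile from the added fluorine, as 3-cyanophenyl is not among the compounds shown. On these data alone, how an amine or a carboxylic acid in place of the nitrile would read also stays open.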